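The compounds below may be only part of what the source reports. "The series", "measured", "known", "first", "only" and "open" are said of these compounds alone.

Three compounds have been measured in a functional assay on DLD-1 cells (Homo sapiens) for cytotoxicity, with a stated time of 48 h; a higher number here means a weaker inhibitor, a lower number a stronger inhibitor:

compound 1, `CCCCCOc1ccc2oc(/C=C/[S+](C)[O-])cc(=O)c2c1` — 6600 nM
compound 2, `CCCCOc1ccc2oc(/C=C/[S+](C)[O-])cc(=O)c2c1` — 4800 nM
compound 3, `CCC(=O)Oc1ccc2oc(/C=C/[S+](C)[O-])cc(=O)c2c1` — 9000 nM

Compound 1 and compound 2 share a core and differ by methyl in place of hydrogen on a saturated chain carbon, four bonds along the chain from an oxygen on an aromatic ring. That change gave a 1.4-fold higher number from compound 2 to compound 1 (0.14 log units; within the scatter). Compound 3 carries a different core, and how its core differs from that of compound 2 is counted as propanoyl in place of butyl on an oxygen on an aromatic ring. In this assay compound 3 gives 9000 nM, and the step of a 1.9-fold higher number from compound 2 to compound 3 (0.27 log units; within the scatter) together with a 1.4-fold higher number from compound 1 to compound 3 (0.13 log units; within the scatter) shows that all three numbers lie within the scatter of one another, so no order among them can be read.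

Compound 4, `CC(C)C(=O)Oc1ccc2oc(/C=C/[S+](C)[O-])cc(=O)c2c1`, has not yet been measured. It is made from compound 3 by methyl in place of hydrogen on a saturated chain carbon bound to a carbonyl carbon and a saturated chain carbon. Among the compounds with values here, this is the same kind of change as the one from compound 2 to compound 1, but the place is not the same: there the methyl entered on a saturated chain carbon, four bonds along the chain from an oxygen on an aromatic ring, whereas here it enters on a saturated chain carbon bound to a carbonyl carbon and a saturated chain carbon. Because the earlier instance gave only a 1.4-fold higher number from compound 2 to compound 1 (0.14 log units; within the scatter), a small step is expected here as well, estimated as a 1.1-fold higher number from compound 3 to compound 4 (0.05 log units; within the scatter). Compound 4 is therefore expected to give about 10000 nM in this assay, most likely between 5000 nM and 22000 nM.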

Compound 4, half-maximal inhibitory concentration: 9100 nM
Beside the measured number, compound 4's estimate is 1.1-fold (0.04 log units) above it, within the range that was stated.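

In this assay, methyl in place of hydrogen on the propanoyl group gave a 1.0-fold higher number from compound 3 to compound 4 (0.00 log units; within the scatter), while isopropylcarbonyl in place of butyl gave a 1.9-fold higher number from compound 2 to compound 4 (0.28 log units; within the scatter) and isopropylcarbonyl in place of pentyl gave a 1.4-fold higher number from compound 1 to compound 4 (0.14 log units; within the scatter), so none of these steps separates the compounds. Within this small set, the methyl change carries from one core to the other without a measurable difference in its step: the same change on two cores in this assay, a 1.4-fold higher number (0.14 log units; within the scatter) from compound 2 to compound 1 and a 1.0-fold higher number (0.00 log units; within the scatter) from compound 3 to compound 4, 1.4-fold (0.13 log units) apart, within the scatter of two such steps. Within the data shown here, this agreement shows only that the change stayed too small to read in two instances, at two different places on two different chains; it does not show that the methyl has no effect elsewhere, or that the same result would hold on a further core.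

The compounds shown leave open whether a group of another kind on the oxygen on the aromatic ring, such as a chain ending in an amine or a carboxylic acid, or a chain longer than pentyl, would give a step beyond the scatter. They also leave open whether the methyl change would behave the same way in a different cell line.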